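A few compounds are considered here, and "the series" means these few. Any claim that something is new, unique, unknown or untested is made for them only; others in the source may bear on it.

Measured so far:
compound 1 `CC(C)Oc1ccc(CNC(=O)c2ccc(C(C)(C)C)cc2)cc1` — in an assay on HeLa cells with Bile acid receptor (Homo sapiens) as the target, read by a luciferase reporter, with a stated time of 24 h (on this read-out lower numbers stand for an effect already at smaller amounts and higher numbers for an effect only at larger amounts of compound), compound 1 gives 170 nM
compound 2 `CC(C)(C)c1ccc(C(=O)NCc2ccc(NS(C)(=O)=O)cc2)cc1` — in this assay compound 2 gives 44 nM
compound 3 `CC(C)(C)c1ccc(C(=O)NCc2ccc(SC(F)(F)F)cc2)cc1` — in this assay compound 3 gives 0.4 nM

Compound 3 holds the lowest number of the three in this assay: the step of a 110-fold lower number from compound 2 to compound 3 (2.04 log units; beyond the scatter) and the step of a 430-fold lower number from compound 1 to compound 3 (2.63 log units; beyond the scatter) are both large and both beyond the scatter, so it is the strongest of the measured set by a clear margin. Between the other two, the step of a 3.9-fold lower number from compound 1 to compound 2 (0.59 log units; beyond the scatter) is modest.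

Compound 4 `CC(C)(C)c1ccc(C(=O)NCc2ccc(OCC(=O)O)cc2)cc1` is not yet measured. It differs from compound 3 in one place: carboxymethoxy in place of (trifluoromethyl)sulfanyl on an aromatic carbon.

Going by the values given here, no measured step exchanges exactly these two groups. Among the compounds with values here, the steps that bear on it are the two that lead into compound 3, a 430-fold lower number from compound 1 to compound 3 (2.63 log units; beyond the scatter) and a 110-fold lower number from compound 2 to compound 3 (2.04 log units; beyond the scatter), each showing that removing (trifluoromethyl)sulfanyl in favour of an oxygen- or nitrogen-bearing group costs a large amount in this assay. Carboxymethoxy is such a group, so a large rise in number is expected for compound 4, of about a 750-fold higher number from compound 3 to compound 4 (2.88 log units; beyond the scatter), landing near the region of compound 1 and compound 2 rather than compound 3. The estimate for compound 4 in this assay is 300 nM, with a range from 30 nM to 3000 nM.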

Compound 4, half-maximal effective concentration: 730 nM
Compound 4: the middle estimate sits 2.4-fold (0.39 log units) below what was measured; measured number inside the range.
By their numbers in this assay, from the lowest: compound 3; then compound 2; then compound 1; then compound 4.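

In this assay, carboxymethoxy gives the highest number of the four compounds, and a 1800-fold higher number from compound 3 to compound 4 (3.26 log units; beyond the scatter) is the largest step seen so far on this aromatic carbon, para to a large group. Keeping the oxygen on the aromatic ring and changing only what it carries still moves the number, with carboxymethyl in place of isopropyl giving a 4.3-fold higher number from compound 1 to compound 4 (0.63 log units; beyond the scatter), so an oxygen at this place does not by itself fix the level, while a 17-fold higher number from compound 2 to compound 4 (1.22 log units; beyond the scatter) separates carboxymethoxy from methanesulfonamido even though both stand far from compound 3. No measurement of any property of these groups accompanies the series to account for these steps.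

Open, from the compounds shown here alone, is whether the high number of compound 4 goes with the free carboxylic acid, which a methyl ester or a primary amide on the same chain would test, or with the chain itself, which a longer chain ending in the same acid would probe. Also open, going by these compounds, is whether the sulfur of compound 3 matters, which trifluoromethoxy or trifluoromethyl at this place would show.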